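Carbamoyl on the outer phenyl ring of compound 1

The source may hold more compounds than are shown below. What is called first, only, known or untested is meant among the compounds shown, and "the series" means these compounds.

compound 1 `CC(=O)NCCN(C)c1cccc(OCCCCCCNC(=O)Oc2cccc(-c3ccccc3)c2)c1`: 0.75
compound 2 `CC(=O)NCCN(C)c1cccc(OCCCCCCN)c1`: 0.08
compound 3 `CC(=O)NCCN(C)c1cccc(OCCCCN)c1`: 0.35

All three were run in a functional assay on cells for agonist activity at melatonin receptor type 1B (Homo sapiens), read by GTPgammaS binding, with a stated time of 30 min; on this read-out higher numbers stand for larger maximal responses and lower numbers for smaller maximal responses. Compound 1 stands highest of the three; compound 3 is nearest and compound 2 furthest, both gaps beyond the scatter. For the measured compounds named here, the only measured step, a number 0.27 higher from compound 2 to compound 3 (beyond the scatter), is an amino in place of 2-aminoethyl on the saturated chain and does not touch the ring that is changed here.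

Compound 4 `CC(=O)NCCN(C)c1cccc(OCCCCCCNC(=O)Oc2cccc(-c3cccc(C(N)=O)c3)c2)c1` differs from compound 1 by carbamoyl in place of hydrogen on an aromatic carbon. Going by the values given here, no measured step bears on this change, so the expectation rests on compound 1 alone: no step beyond the scatter is expected, a number 0.050 lower from compound 1 to compound 4 (within the scatter). The estimate for compound 4 in this assay is 0.7, between 0.5 and 0.9.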

Compound 4, intrinsic activity: the largest response reached, as a fraction of the reference agonist's: 1.01
For compound 4 the middle estimate is 0.31 below the measured one; the whole stated range lies below it.
By their numbers in this assay, from the lowest: compound 2; then compound 3; then compound 1; then compound 4.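

On the phenyl ring of compound 1, at the aromatic carbon meta to a large group, carbamoyl in place of hydrogen gives a number 0.26 higher from compound 1 to compound 4 (beyond the scatter). In this assay, for the compounds shown here, this shows that the maximal response can be moved from this ring, which the chain step among the earlier compounds could not show. No available data give a reason for this rise. From the compounds shown here alone, whether a carboxylic acid, a nitrile or an aminomethyl group at this place would do the same stays open. So does the effect of carbamoyl elsewhere on this ring.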